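Nitro to Benzyloxy on Two Related Cores

The source may report more compounds than this note shows. Statements on the series, on what has been measured and on what is new or still open speak of the compounds shown alone.

Compound 1 `CCOC(=O)c1cc(-c2cc(OC)c(OC)c(OC)c2)c(-c2ccc(OC)c([N+](=O)[O-])c2)s1` gives 15800 nM in a functional assay on KB cells (Homo sapiens) for antiproliferative activity, read by MTT assay, with a stated time of 72 h; a higher number here means a weaker inhibitor, a lower number a stronger inhibitor. Compound 3 `COc1ccc(-c2sccc2-c2cc(OC)c(OC)c(OC)c2)cc1[N+](=O)[O-]` gives 10600 nM in this assay. Compound 2 `CCOC(=O)c1cc(-c2cc(OC)c(OC)c(OC)c2)c(-c2ccc(OC)c(OCc3ccccc3)c2)s1` reaches only a limit of the assay, > 100000 nM.

Compound 1 and compound 3 carry different cores: the difference is hydrogen in place of ethoxycarbonyl on an aromatic carbon, and the measured step for it is a 1.5-fold lower number from compound 1 to compound 3 (0.17 log units; within the scatter). Compound 2 differs from compound 1 by benzyloxy in place of nitro on an aromatic carbon, which produced a step of an at least 6.3-fold higher number from compound 1 to compound 2 (0.80 log units; beyond the scatter); the measurement ended at the limit of > 100000 nM in this assay, at which 1 of the 3 values shown sits, so only a lower bound of the weakening is known.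

Compound 4 `COc1ccc(-c2sccc2-c2cc(OC)c(OC)c(OC)c2)cc1OCc1ccccc1` is not yet measured. It differs from compound 3 by benzyloxy in place of nitro on an aromatic carbon, the same change at the same place, made on the other core. Because the earlier step was an at least 6.3-fold higher number from compound 1 to compound 2 (0.80 log units; beyond the scatter), compound 4 is expected to show a step of about an 8.5-fold higher number from compound 3 to compound 4 (0.93 log units; beyond the scatter) in this assay, with a real chance that the assay again reports only a limit. Compound 4 is estimated to give 90000 nM, most likely between 30000 nM and 300000 nM.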

Compound 4, half-maximal inhibitory concentration: > 100000 nM
Compound 4: a limit, no number (the forecaster's own chance of this, stated with the estimate: 55%); middle value at least 1.1-fold (0.04 log units) away from the limit.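

In this assay, benzyloxy in place of nitro gives an at least 9.4-fold higher number from compound 3 to compound 4 (0.97 log units; beyond the scatter), so the weakening seen on the core of compound 1 appears again on the core of compound 3. The direction of the change therefore carries over between these two cores, but its size on each core is not pinned down, and nothing shows that it would carry over to any further core: the same change on two cores in this assay, an at least 6.3-fold higher number (0.80 log units; beyond the scatter) from compound 1 to compound 2 and an at least 9.4-fold higher number (0.97 log units; beyond the scatter) from compound 3 to compound 4; the limit leaves it open whether they differ. Compound 4 gives > 100000 nM, which is a limit and not a number, and the step between compound 2 and compound 4 cannot be read, so these two compounds do not show what removing ethoxycarbonyl does when benzyloxy is present.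

Only nitro and benzyloxy are shown at this place, so it remains open how an amine, a hydroxyl group or a short ether such as ethoxy would behave there. Also open, going by these compounds, is whether either core would respond to such a group in the same way.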